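This account rests on a few compounds, and the source may have more. Where it says the series, first, only, none or still open, it means among the compounds named here.

Compound 1 `C=CS(=O)(=O)NC/C=C/c1cc(OC)cc(O)c1C(=O)OCC1CCCCC1`: 31.2%
Compound 2 `COc1cc(O)c(C(=O)OCC(C)c2ccccc2)c(/C=C/CN2C(=O)C=CC2=O)c1`: 0%
Compound 3 `CCN(CC)C/C=C/C(=O)NC/C=C/c1cc(OCCc2ccc(F)cc2)cc(O)c1C(=O)OC(C)C`: 28.5%

All three compounds were tested in an ADME assay on HEK-293T cells (Homo sapiens) for inhibition, read by luminescence, with a stated time of 72 h, tested at 5 uM; on this read-out lower numbers stand for less inhibition of growth and higher numbers for more inhibition of growth at the one concentration tested. Compound 1, at 31.2%, stands level with compound 3 within the scatter, while the gap between compound 1 and compound 2 lies beyond the scatter.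

Compound 4 `C=CS(=O)(=O)NC/C=C/c1cc(OC)cc(O)c1C(=O)OCc1ccc(F)cc1` has not yet been measured. It keeps the core of compound 1 and changes only the ester side: 4-fluorophenyl in place of cyclohexyl on a saturated chain carbon bound to an oxygen next to a carbonyl group. In words, 4-fluorophenyl takes the place of cyclohexyl on a saturated chain carbon bound to an oxygen next to a carbonyl group, so cyclohexylmethyl becomes 4-fluorobenzyl.

Among the measured compounds shown here, no two measured compounds differ in one place only, so the data hold no direct precedent for this change. The expectation is therefore for no change beyond the scatter in this assay, with a slight lean downward. The estimated step is a number 3.2 percentage points lower from compound 1 to compound 4 (within the scatter). The range is kept wide, since compound 2 reads 0% and shows that a compound of this set can give no measurable inhibition. For compound 4 the expected value is 28%, with an estimated range from 8% to 48%.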

Compound 4, percent growth inhibition at one concentration: 0%
Compound 4: the middle estimate sits 28 percentage points above what was measured; measured number below the stated range.
By their numbers in this assay, from the lowest: compounds 2 and 4 (each within the scatter of the next); then compounds 3 and 1 (each within the scatter of the next).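

In this assay the ester side proves to be a place where a single exchange can decide the read-out: with the shared core held fixed, 4-fluorophenyl in place of cyclohexyl on a saturated chain carbon bound to an oxygen next to a carbonyl group gives a number 31.2 percentage points lower from compound 1 to compound 4 (beyond the scatter). Among the compounds shown here, this is the only pair in the set that differs in one place, and it shows that the growth inhibition seen with cyclohexylmethyl does not carry over to 4-fluorobenzyl, even though both groups hold a six-membered ring of carbon on the same chain carbon and match in hydrogen-bond donors, hydrogen-bond acceptors and net charge; what differs is an aromatic ring for a non-aromatic one, together with the fluorine. Nothing at hand explains this drop.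

The pair cannot separate the aromatic ring from the fluorine, so the plain benzyl ester, which has the ring without the fluorine, remains the open case. Also open, from the compounds shown here alone, is how far the drop extends to other esters at this place, such as a cyclopentylmethyl ester or a longer chain like 2-cyclohexylethyl.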